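Two Nitrophenyl Analogues and a Third Awaiting Its Number

The compounds below may be only part of what the source reports. "The series", "measured", "known", "first", "only" and "open" are said of these compounds alone.

The study includes two compounds with a measured result. Compound 1 has the structure `O=[N+]([O-])c1ccc(C2=Nn3c(Cc4ccc5ccccc5c4)nnc3SC2)cc1` and, in a toxicity assay on Vero cells (Chlorocebus sabaeus) for cytotoxicity, read by resazurin assay (on this read-out lower numbers stand for stronger inhibition and higher numbers for weaker inhibition), compound 1 gives 69700 nM. Compound 2 has the structure `O=[N+]([O-])c1ccc(C2=Nn3c(nnc3-c3ccncc3F)SC2)cc1` and, in this assay, compound 2 gives 355000 nM, the highest of the two numbers, with compound 1 standing beyond the scatter from it. The not yet measured compound 3 has the structure `O=[N+]([O-])c1ccc(C2=Nn3c(nnc3-c3ccc(Br)cc3)SC2)cc1`. Compared with compound 2, the change is 4-bromophenyl in place of 3-fluoropyridin-4-yl on an aromatic carbon, which puts 4-bromophenyl in place of 3-fluoropyridin-4-yl on an aromatic carbon. Within the data shown here, no measured pair shows a step of this kind, so there is no direct precedent. Compound 3 is expected to show a moderate move toward the lower number of compound 1, the step from a 2.2-fold lower number from compound 2 to compound 3 (0.35 log units; beyond the scatter) being the estimate. Compound 3 is thus estimated at 160000 nM, within a range from 50000 nM to 450000 nM.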

Compound 3, half-maximal inhibitory concentration: 13900 nM
Estimate against measurement, compound 3: 12-fold (1.06 log units) above; measured number outside the range, below it.
By their numbers in this assay, from the lowest: compound 3; then compound 1; then compound 2.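

At this aromatic carbon of the five-membered aromatic ring with 3 nitrogen, putting 4-bromophenyl in place of 3-fluoropyridin-4-yl gives, in this assay, a 26-fold lower number from compound 2 to compound 3 (1.41 log units; beyond the scatter) and so a large move toward stronger inhibition. Among these compounds, the earlier compounds offered no step at all, so this is the first direct sign that the group at this position can shift the number strongly, even though both groups count 7 heavy atoms and one six-membered aromatic ring. Nothing measured here gives a reason for the size of this step.

The change swaps the ring nitrogen, the fluorine and the bromine together, so the compounds shown do not separate their shares in the step. They also leave open how an unsubstituted phenyl, a 4-chlorophenyl or an amine-bearing phenyl would read at this carbon.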